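The compounds below may be only part of what the source reports. "The series", "measured", "known", "first", "only" and "open" are said of these compounds alone.

Measured compounds:
compound 1 `O=C(Nc1cccc(-n2cc(-c3ccncc3)c(-c3ccc(Cl)c(O)c3)n2)c1)Nc1cccc(C(F)(F)F)c1` gives > 32500 nM
compound 2 `O=C(Nc1cccc(-n2cc(-c3ccncc3)c(-c3ccc(Cl)c(O)c3)n2)c1)Nc1ccc(Cl)c(Cl)c1` gives > 32500 nM

Both numbers come from a functional assay on K562 cells (Homo sapiens) for inhibition, read by sulforhodamine B assay, with a stated time of 48 h; on this read-out lower numbers stand for higher toxicity in this test and higher numbers for lower toxicity in this test. For compound 1 the result is only a limit of the test, > 32500 nM, not a measured number. Compound 2 likewise stops at a limit, > 32500 nM. So compound 1 stands at the edge of what this assay can report, and the one other value shown stands there too (the limit of > 32500 nM in this assay, at which 2 of the 2 values shown sit).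

Among the compounds with values here, the only measured step between neighbours, a step that the two limits leave unreadable from compound 1 to compound 2, exchanges the ring on the amide-type nitrogen; its size cannot be read, since both ends are limits.

Compound 3 `O=C(Nc1cccc(-n2cc(-c3ccncc3)c(-c3ccc(Cl)c(O)c3)n2)c1)Nc1cc(C(F)(F)F)cc(C(F)(F)F)c1` arises from compound 1 by trifluoromethyl in place of hydrogen on an aromatic carbon. Within the data shown here, this change sits on the same ring as the one measured step, which altered that ring without moving the result off the limit.

Among the measured compounds shown here, with that as the only guide, compound 3 is expected to remain at the limit as well. The step from compound 1 to compound 3 in this assay is estimated at a step that the limit leaves unreadable from compound 1 to compound 3, meaning no change beyond the scatter. Compound 3 is estimated at 40000 nM, within 15000 nM to 100000 nM.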

Compound 3, concentration lethal to 50% of the cells: > 50000 nM
Compound 3 was reported as a limit; the forecaster's own chance of this, stated with the estimate: 85%; at least 1.2-fold (0.09 log units) between middle value and limit.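

Compound 1 and compound 3 both stop at a limit of the test, not a measured number, and the size of the step between them cannot be read. The compounds shown leave open what concentration, if any, of compound 1, compound 2 or compound 3 would reach a measured value in this assay, and whether changing this ring alters that value.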